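One Change Measured Once, Expected Again

A few compounds are considered here, and "the series" means these few. Any claim that something is new, unique, unknown or untested is made for them only; others in the source may bear on it.

Of the compounds shown here, three have been measured in a functional assay on DU-145 cells (Homo sapiens) for antiproliferative activity, read by fluorescence and propidium iodide staining, with a stated time of 96 h; on this read-out lower numbers stand for stronger inhibition and higher numbers for weaker inhibition. Compound 1 `O=C(Nc1ccc(S(F)(F)(F)(F)F)cc1)c1ccc(Sc2ccc(O)cc2)cc1` gives 6760 nM. Compound 3 `O=C(Nc1ccc(S(F)(F)(F)(F)F)cc1)c1ccc([S+]([O-])c2ccc(O)cc2)cc1` differs from compound 1 in one place, (a group of 9 heavy atoms (6 carbon, 2 oxygen, 1 sulfur; one six-membered aromatic ring of carbon only) in place of a group of 8 heavy atoms (6 carbon, 1 oxygen, 1 sulfur; one six-membered aromatic ring of carbon only), on an aromatic carbon), and in this assay compound 3 gives 11000 nM. The step of a 1.6-fold higher number from compound 1 to compound 3 (0.21 log units; within the scatter) is small by the standard of repeated measurements of this kind. Compound 2 `O=C(Nc1ccccc1C(F)(F)F)c1ccc(Sc2ccc(O)cc2)cc1` is built on a different core; how the core of compound 2 differs from the core of compound 1 is not broken down here. In this assay compound 2 gives 35700 nM, the highest of the three numbers, and its gaps to compound 3 and to compound 1 both lie beyond the scatter.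

Compound 4 `O=C(Nc1ccccc1C(F)(F)F)c1ccc([S+]([O-])c2ccc(O)cc2)cc1` has not yet been measured. It stands to compound 2 as compound 3 stands to compound 1: the change is a group of 9 heavy atoms (6 carbon, 2 oxygen, 1 sulfur; one six-membered aromatic ring of carbon only) in place of a group of 8 heavy atoms (6 carbon, 1 oxygen, 1 sulfur; one six-membered aromatic ring of carbon only), on an aromatic carbon. The place of the change reads the same in both cases, so this is the same change made on a second core.

Going by the values given here, the only guide to what this change does is the one measured step. Because a 1.6-fold higher number from compound 1 to compound 3 (0.21 log units; within the scatter) is a small rise, the expected step is a 1.5-fold higher number from compound 2 to compound 4 (0.19 log units; within the scatter), about the same in size and direction. That rests on a single pair, so the uncertainty is wide. Compound 4 is therefore estimated to give 55000 nM in this assay, with the range from 25000 nM to 120000 nM expected to hold most repeat measurements.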

Compound 4, half-maximal inhibitory concentration: 100000 nM
Compound 4: middle estimate off by 1.8-fold (0.26 log units), on the low side, within the range that was stated.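

Going by these compounds alone, on the second core, the change away from the (4-hydroxyphenyl)sulfanyl group gives a 2.8-fold higher number from compound 2 to compound 4 (0.45 log units; beyond the scatter) in this assay, so the number goes up here just as it does on the first core, although only this second step lies beyond the scatter. Set side by side, the two steps cannot be told apart, so the change carries over from one core to the other as far as these data can show: the same change on two cores in this assay, a 1.6-fold higher number (0.21 log units; within the scatter) from compound 1 to compound 3 and a 2.8-fold higher number (0.45 log units; beyond the scatter) from compound 2 to compound 4, 1.7-fold (0.24 log units) apart, within the scatter of two such steps This is still only two pairs in a single assay, so it shows neither that the same step would appear on a third core nor why the change raises the number on the second core.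

The compounds shown also leave open what happens when the link between the two rings is taken further, for example to a sulfonyl group with two oxygens on the sulfur, or is replaced by a plain methylene group. On these data alone, they likewise keep the hydroxyl group throughout, so it remains unknown whether the same step would appear if an amine or a carboxylic acid stood in its place.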